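This account rests on a few compounds, and the source may have more. Where it says the series, first, only, none or still open, it means among the compounds named here.

Measured in a functional assay on a cell-free system (plasma, Homo sapiens), with a stated time of 3 min; on this read-out higher numbers stand for weaker inhibition and lower numbers for stronger inhibition:
- compound 1 `O=C(NCc1cc(Cl)ccc1-n1cnnn1)[C@@H]1C[C@@H]2C[C@@H]2N1C(=O)[C@H](O)CC1CC1` gives 1700 nM
- compound 2 `O=C(NCc1cc(Cl)ccc1-n1cnnn1)[C@@H]1C[C@@H]2C[C@@H]2N1C(=O)[C@H](O)c1cccc(Cl)c1` gives 1000 nM
- compound 3 `O=C(NCc1cc(Cl)ccc1-n1cnnn1)[C@@H]1[C@@H]2C[C@@H]2CN1C(=O)[C@H](O)Cc1ccccn1` gives 1700 nM

Compound 3 stands level with compound 1 at the digits shown, and its gap to compound 2 lies within the scatter. Compound 4 `O=C(NCc1cc(Cl)ccc1-n1cnnn1)[C@@H]1[C@@H]2C[C@@H]2CN1C(=O)[C@H](O)Cc1ccccc1` differs from compound 3 in one place phenyl in place of pyridin-2-yl on a saturated chain carbon, two bonds along the chain from a carbonyl carbon and an oxygen on a saturated carbon with phenyl in place of pyridin-2-yl on a saturated chain carbon. Within the data shown here, the one measured single-place step, a 1.7-fold lower number from compound 1 to compound 2 (0.23 log units; within the scatter), stayed within the scatter, though it swapped other groups. Among the measured compounds shown here, no measured step makes this exact swap, so this assay is expected to show no change beyond the scatter. The expected step, a 1.3-fold lower number from compound 3 to compound 4 (0.12 log units; within the scatter), is estimated to stay within that scatter. For compound 4 the estimated value is 1300 nM, expected to fall between 450 nM and 3500 nM in most repeat measurements.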

Compound 4, half-maximal inhibitory concentration: 970 nM
Beside the measured number, compound 4's estimate is 1.3-fold (0.13 log units) above it; low and high end bracket the measured number.
By their numbers in this assay, from the lowest: compounds 4, 2, 1 and 3 (each within the scatter of the next).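

In this assay, the swap at this position, on a saturated chain carbon two bonds along the chain from a carbonyl carbon and an oxygen on a saturated carbon, gives a 1.8-fold lower number from compound 3 to compound 4 (0.24 log units; within the scatter), so the two compounds cannot be told apart. Here the ring nitrogen of pyridin-2-yl, the group's one hydrogen-bond acceptor, can be exchanged for carbon with no difference beyond the scatter. No supporting data bear on why this is so.

As far as these compounds go, whether an amine or a carboxylic acid in place of phenyl would give a number beyond the scatter stays open.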